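A small swap on the higher compound

This account rests on a few compounds, and the source may have more. Where it says the series, first, only, none or still open, it means among the compounds named here.

Compound 1 `CC(=O)NCCS(=O)(=O)c1ccc(S(=O)(=O)c2ccc(CN)s2)cc1`: 380 nM
Compound 2 `CC(C)(C)c1cc(S(C)(=O)=O)cc(S(=O)(=O)c2ccc(CN)s2)c1`: 16000 nM

Both values come from an ADME assay on the whole organism (Mus musculus) for pharmacokinetics, at a dose of 50 mg/kg by the oral route; a higher number here means more compound in the circulation at the dose given, a lower number less compound in the circulation. Compound 2, at 16000 nM, stands highest of the two, and the gap down to compound 1, at 380 nM, lies well beyond the usual scatter. Among the measured compounds shown here, these two compounds differ in more than one place, so no measured step shows what a single change does here.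

Compound 3 `CC(C)(C)Oc1cc(S(C)(=O)=O)cc(S(=O)(=O)c2ccc(CN)s2)c1` carries tert-butoxy in place of tert-butyl on an aromatic carbon. The rest of the structure matches compound 2, so the estimate starts from compound 2 at 16000 nM. The expected step is small and downward, within or near the scatter: a 1.8-fold lower number from compound 2 to compound 3 (0.25 log units; within the scatter). For compound 3 the estimated value is 9000 nM, with an expected range of 2500 nM to 25000 nM.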

Compound 3, maximal plasma concentration: 6300 nM
Estimate against measurement, compound 3: 1.4-fold (0.15 log units) above; the measured number falls inside the stated range.
By their numbers in this assay, from the lowest: compound 1; then compound 3; then compound 2.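

Among the compounds shown here, compounds 1 and 2 differ in more than one place, so this is the first single change that can be read in this assay. Putting tert-butoxy in place of tert-butyl, on an aromatic carbon meta to a methylsulfonyl group, gives a 2.5-fold lower number from compound 2 to compound 3 (0.40 log units; beyond the scatter), a modest step that lies beyond the usual scatter, so this position does respond to the swap, though not dramatically. No accompanying measurement bears on why the number moves.

As far as these compounds go, it remains open whether a methoxy group, an amine or a longer chain at this position would move the number in the same direction or by a similar amount. This single step also cannot separate the effect of the added oxygen from that of the tert-butoxy group as a whole.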